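Removing one methoxy from the trimethoxyphenyl of compound 3

The source may report more compounds than this note shows. Statements on the series, on what has been measured and on what is new or still open speak of the compounds shown alone.

Three compounds of this series carry a measured number in a functional assay on MDA-MB-231 cells (Homo sapiens) for inhibition, read by MTT assay, with a stated time of 48 h; a lower number here means a stronger inhibitor, a higher number a weaker inhibitor. Compound 1 `COc1ccc(-c2nc3cc(/C=C4\SC(=O)NC4=O)ccc3[nH]2)cc1OC` gives 13600 nM in this assay. Compound 2 `COc1cc(OC)c(-c2nc3cc(/C=C4\SC(=O)NC4=O)ccc3[nH]2)cc1OC` gives 24500 nM in this assay. Compound 3 `COc1cc(CN2C(=O)S/C(=C\c3ccc4[nH]c(-c5cc(OC)c(OC)c(OC)c5)nc4c3)C2=O)cc(OC)c1OC` gives 270 nM in this assay, the lowest of the three, and its distance to compound 1 and to compound 2 lies beyond the scatter, so compound 3 is the strongest inhibitor among the measured compounds. The difference between the cores of compound 3 and compound 2 is not broken down here.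

Between compound 2 and compound 1 the change is hydrogen in place of methoxy on an aromatic carbon, and it gives a 1.8-fold lower number from compound 2 to compound 1 (0.26 log units; within the scatter).

Compound 4 `COc1ccc(-c2nc3cc(/C=C4\SC(=O)N(Cc5cc(OC)c(OC)c(OC)c5)C4=O)ccc3[nH]2)cc1OC` has not yet been measured. It differs from compound 3 by hydrogen in place of methoxy on an aromatic carbon. This is the same kind of change as from compound 2 to compound 1, not the same: in compound 2 the methoxy that leaves sits ortho to a large group, meta to a methoxy group and para to a methoxy group, whereas in compound 3 it sits ortho to a methoxy group, meta to a large group and meta to a methoxy group.

Given that compound 2 to compound 1 stayed within the scatter with a 1.8-fold lower number from compound 2 to compound 1 (0.26 log units; within the scatter), a small step is expected for compound 4 too, estimated as a 1.5-fold higher number from compound 3 to compound 4 (0.17 log units; within the scatter) in this assay. Compound 4 is expected to give about 400 nM in this assay, with a likely range from 150 nM to 1200 nM.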

Compound 4, half-maximal inhibitory concentration: 29100 nM
The estimate for compound 4 lay 73-fold (1.86 log units) below the measured number; the whole stated range lies below it.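

Replacing methoxy with hydrogen, read here as 3,4,5-trimethoxyphenyl to 3,4-dimethoxyphenyl on the core of compound 3, gives in this assay a 110-fold higher number from compound 3 to compound 4 (2.03 log units; beyond the scatter), so on this core the change is far from neutral. The same change therefore does not carry over unchanged between the two cores in this series, and a step measured on one core is a poor guide to the step on the other: the same change on two cores in this assay, a 1.8-fold lower number (0.26 log units; within the scatter) from compound 2 to compound 1 and a 110-fold higher number (2.03 log units; beyond the scatter) from compound 3 to compound 4, 190-fold (2.29 log units) apart, beyond the scatter of two such steps
For the compounds shown here, this does not show what sets the two steps apart, since only two pairs are available, the methoxy that leaves does not sit in the same place on the ring in each pair, and the cores differ by more than one feature, so neither the place of the methoxy nor any single feature of the core can be singled out as the source of the gap.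

Open, going by these compounds, is how the core of compound 3 responds when another group, such as a hydroxyl, an ethoxy or an amine, stands in the place of the methoxy that left. Also open, on these data alone, is whether removing either of the other two methoxy groups of the 3,4,5-trimethoxyphenyl gives a step of similar size on that core.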